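The compounds below may be only part of what the source reports. "The series", "measured", "known", "first", "only" and "open" are said of these compounds alone.

Compound 1 `CN(C(=O)NC(=O)c1c(F)cccc1F)c1nc(C(F)(F)F)c(C(=O)N/N=C/c2cc(C(F)(F)F)cc(C(F)(F)F)c2)s1` gives 5.28 ug/mL in a functional assay on BCG823 cells (Homo sapiens) for inhibition, read by MTT assay, with a stated time of 72 h; on this read-out lower numbers stand for stronger inhibition and higher numbers for weaker inhibition.
Compound 2 `CN(C(=O)NC(=O)c1c(F)cccc1F)c1nc(C(F)(F)F)c(C(=O)N/N=C/c2cccc(C(F)(F)F)c2)s1` gives 25.9 ug/mL in this assay.

Among the compounds with values here, compound 1 stands with the lower of the two numbers; the only measured step, a 4.9-fold higher number from compound 1 to compound 2 (0.69 log units; beyond the scatter), was made on an aromatic carbon of the hydrazone side of the shared core. Compound 3 `CN(C(=O)NC(=O)c1cccc(C(F)(F)F)c1)c1nc(C(F)(F)F)c(C(=O)N/N=C/c2cc(C(F)(F)F)cc(C(F)(F)F)c2)s1` differs from compound 1 elsewhere: 3-(trifluoromethyl)phenyl in place of 2,6-difluorophenyl on a carbonyl carbon. No measured step touches that carbonyl carbon, so nothing shown bears directly on the change, and no step beyond the scatter is expected in this assay. Compound 3 is therefore estimated at 6 ug/mL, in the range 2 ug/mL to 18 ug/mL, which means an expected step of a 1.1-fold higher number from compound 1 to compound 3 (0.06 log units; within the scatter).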

Compound 3, half-maximal inhibitory concentration: 5.23 ug/mL
Beside the measured number, compound 3's estimate is 1.1-fold (0.06 log units) above it; low and high end bracket the measured number.
By their numbers in this assay, from the lowest: compounds 3 and 1 (each within the scatter of the next); then compound 2.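

Exchanging 2,6-difluorophenyl for 3-(trifluoromethyl)phenyl on the carbonyl carbon gives a 1.0-fold lower number from compound 1 to compound 3 (0.00 log units; within the scatter) in this assay. Within the data shown here, this is the first view of that end of the molecule: there, one fluorinated aromatic ring can replace another with no change that can be told from the scatter. No measurement shown explains why the two groups read alike.

A longer alkyl chain, or a phenyl ring carrying an amine or a carboxylic acid, on that carbonyl carbon remains untested among these compounds. Among these compounds, whether the same exchange holds with the single trifluoromethyl of compound 2 also remains open.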